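The source may report more compounds than this note shows. Statements on the series, on what has been measured and on what is new or still open speak of the compounds shown alone.

Measured so far in a functional assay on SN12C cells (Homo sapiens) for inhibition, with a stated time of 48 h; on this read-out lower numbers stand for stronger inhibition of growth and higher numbers for weaker inhibition of growth:
compound 1 `COc1c(C(=O)/C=C/c2ccc(Cl)cc2)c(O)c(Br)c2occc12` with 3770 nM
compound 2 `C=CCc1c(O)c(C(=O)/C=C/c2ccccc2)c(OC)c2ccoc12` with 3790 nM

Compound 2 (3790 nM) stands level with compound 1 (3770 nM), since the two values lie within the scatter of each other and show no order. Compound 3 `C=CCc1c(O)c(C(=O)/C=C/c2ccc(Cl)cc2)c(OC)c2ccoc12` has not yet been measured. It differs from compound 2 in one place, with chloro in place of hydrogen on an aromatic carbon, para to a large group, so that phenyl becomes 4-chlorophenyl (chloro in place of hydrogen on an aromatic carbon). For the measured compounds named here, no measured pair shows this change on its own, so the expectation in this assay is only a small move towards a lower number, probably not beyond the scatter. The expected size is a 1.3-fold lower number from compound 2 to compound 3 (0.10 log units; within the scatter) on this estimate. Compound 3 is estimated at 3000 nM with an expected range from 1200 nM to 7500 nM in this estimate.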

Compound 3, concentration for 50% growth inhibition: 4960 nM
Estimate against measurement, compound 3: 1.7-fold (0.22 log units) below; the range from low to high includes it.
By their numbers in this assay, from the lowest: compounds 1, 2 and 3 (each within the scatter of the next).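

In this assay, chloro in place of hydrogen on an aromatic carbon, para to a large group, gives a 1.3-fold higher number from compound 2 to compound 3 (0.12 log units; within the scatter) and so does not separate phenyl from 4-chlorophenyl at this place while allyl stands on the core. With 4-chlorophenyl held in both compounds, allyl in place of bromo on an aromatic carbon gives a 1.3-fold higher number from compound 1 to compound 3 (0.12 log units; within the scatter) and likewise does not separate these two groups. Nothing measured on these compounds speaks to the reason for either result.

The compounds shown leave open whether an amine or a carboxylic acid in place of the chloro would move the number beyond the scatter. They also leave open whether a longer chain in place of the allyl would do so.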